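Trifluoromethyl for Methoxy: Expected Shift in Cytotoxicity

This account rests on a few compounds, and the source may have more. Where it says the series, first, only, none or still open, it means among the compounds named here.

Compound 1 `CN(C)CCCCOC(=O)Nc1ccc(Cn2nc(-c3cccnc3)c3ccccc3c2=O)cc1` gives 68000 nM in an ADME assay on Huh-7 cells (Homo sapiens) for cytotoxicity, read by MTT assay, with a stated time of 48 h; on this read-out higher numbers stand for lower toxicity in this test and lower numbers for higher toxicity in this test.
Compound 2 `COc1cccc(-c2nn(Cc3ccc(NC(=O)OCCCCN(C)C)cc3)c(=O)c3ccccc23)c1` gives 17600 nM in this assay.

Among the compounds with values here, of the two numbers measured so far in this assay, compound 2 stands lowest, the more toxic of the pair. Within the data shown here, the one measured step, a 3.9-fold lower number from compound 1 to compound 2 (0.59 log units; beyond the scatter), changes a different part of the shared core than the one now in question. Compound 3 `CN(C)CCCCOC(=O)Nc1ccc(Cn2nc(-c3cccc(C(F)(F)F)c3)c3ccccc3c2=O)cc1` differs from compound 2 only by trifluoromethyl in place of methoxy on an aromatic carbon. Among the measured compounds shown here, no measured step speaks to this exchange, so the only guide is that the single known step was modest and that swaps of one small group on this ring have not moved the number far. The expected step, a 1.2-fold lower number from compound 2 to compound 3 (0.07 log units; within the scatter), is therefore small and not clearly beyond the scatter in either direction. Compound 3 is estimated at 15000 nM, with a plausible range from 5000 nM to 45000 nM.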

Compound 3, half-maximal cytotoxic concentration: 11600 nM
Compound 3: middle estimate off by 1.3-fold (0.11 log units), on the high side, and the stated range covers the measured number.
By their numbers in this assay, from the lowest: compounds 3 and 2 (each within the scatter of the next); then compound 1.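

Exchanging 3-methoxyphenyl for 3-(trifluoromethyl)phenyl gives a 1.5-fold lower number from compound 2 to compound 3 (0.18 log units; within the scatter) in this assay and so leaves these two compounds indistinguishable in this test, although the groups differ in heavy atoms and in hydrogen-bond acceptors. Replacing pyridin-3-yl with 3-(trifluoromethyl)phenyl gives a 5.9-fold lower number from compound 1 to compound 3 (0.77 log units; beyond the scatter) and so shows that, among these three compounds, the clear difference lies between pyridin-3-yl and either substituted phenyl ring, not between the two substituents. Nothing available here explains this result.

Two substituents on a phenyl ring cannot show whether the same would hold for a wider range of groups at this place. From the compounds shown here alone, an amine, a carboxylic acid or a chlorine atom on this ring could behave quite differently, and the effect of a plain phenyl ring also remains open.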